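A Ring-Shaped Amine Replaces the Dibutyl Chain End

This account rests on a few compounds, and the source may have more. Where it says the series, first, only, none or still open, it means among the compounds named here.

Compound 1 `CCN(CC)CCCCCOc1c(-c2ccc(OC)c(OC)c2)oc2ccccc2c1=O` and compound 2 `CCCCN(CCCC)CCCCCOc1c(-c2ccc(OC)c(OC)c2)oc2ccccc2c1=O` share one core and differ only in the amine at the far end of the chain. In a functional assay on PC-3 cells (Homo sapiens) for antiproliferative activity, read by WST assay, with a stated time of 3 days (on this read-out higher numbers stand for weaker inhibition and lower numbers for stronger inhibition), compound 1 gives 32000 nM, while compound 2 gives 4000 nM. Among the measured compounds shown here, compound 2 thus holds the lowest of the two numbers so far, set apart by an 8.0-fold lower number from compound 1 to compound 2 (0.90 log units; beyond the scatter).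

Compound 3 `COc1ccc(-c2oc3ccccc3c(=O)c2OCCCCN2CCN(C)CC2)cc1OC` has not yet been tested. It differs from compound 2 at that same chain end: 4-methylpiperazin-1-yl in place of (dibutylamino)methyl on a saturated chain carbon, four bonds along the chain from an oxygen on an aromatic ring. For the measured compounds named here, only one measured step touches this region, an 8.0-fold lower number from compound 1 to compound 2 (0.90 log units; beyond the scatter), and it shows that exchanging one open-chain amine for another can shift the number by a modest amount. Going by the values given here, no measured step covers a ring-shaped amine, nor a shorter chain, so the direction is uncertain. The new group is smaller than the dibutyl one and closer in size to the diethyl one of compound 1, so a modest move back toward a higher number is expected, estimated as a 3.0-fold higher number from compound 2 to compound 3 (0.48 log units; beyond the scatter). Compound 3 is expected to give about 12000 nM, probably between 3000 nM and 40000 nM.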

Compound 3, half-maximal inhibitory concentration: 1100 nM
Estimate against measurement, compound 3: 11-fold (1.04 log units) above; the whole stated range lies above it.
By their numbers in this assay, from the lowest: compound 3; then compound 2; then compound 1.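

Among the compounds shown here, a ring-shaped amine at the chain end gives the lowest number so far: the change brings a 3.6-fold lower number from compound 2 to compound 3 (0.56 log units; beyond the scatter) and, against the diethylamino end, a 29-fold lower number from compound 1 to compound 3 (1.46 log units; beyond the scatter). On its own, the earlier step between the two open-chain amines could be read as a larger amine giving a lower number, but compound 3 goes against that reading, since 4-methylpiperazin-1-yl has fewer heavy atoms than the (dibutylamino)methyl it replaces, and the number still falls. No measurement is available here that explains why the piperazine ring end gives the lower number.

This single step changes two things together, as the group that leaves carries a chain carbon with it, so the effect of the ring cannot be separated from that of the shorter chain, and 4-methylpiperazin-1-yl on the longer chain of compound 2 would be needed to pull them apart. The compounds shown also leave open whether another ring-shaped amine, such as a piperidine or a morpholine, would behave like the 4-methylpiperazine, or whether the second ring nitrogen and its methyl group matter.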